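Swapping Hydrogen for 4-Nitrophenyl on the Ring Nitrogen

A few compounds are considered here, and "the series" means these few. Any claim that something is new, unique, unknown or untested is made for them only; others in the source may bear on it.

Measured compounds:
Compound 1 `Cc1ccc(C2=NN(c3ccc([N+](=O)[O-])cc3)C(c3cn(-c4ccccc4)nc3-c3ccc(Cl)c(Cl)c3)C2)cc1`: 57.4%
Compound 2 `CCC(=O)N1N=C(c2ccc(F)cc2)CC1c1cn(-c2ccccc2)nc1-c1ccc(Cl)c(Cl)c1`: 51.1%
Compound 3 `Fc1ccc(C2=NNC(c3cn(-c4ccccc4)nc3-c3ccc(Cl)c(Cl)c3)C2)cc1`: 45.7%

In a functional assay on the whole organism (strain Wistar) for inhibition, with Rattus norvegicus as the target, read by paw edema, with a stated time of 30 min, at a dose of 50 mg/kg by the oral route (a higher number here means more inhibition at the dose given (going by the name of the read-out), a lower number less inhibition), compound 3 gives the lowest of the three numbers. Compound 2 sits within the scatter of it, and only compound 1 lies beyond the scatter above it. The step of a number 5.4 percentage points lower from compound 2 to compound 3 (within the scatter) shows that removing the propanoyl from that ring nitrogen changed little.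

Compound 4 `O=[N+]([O-])c1ccc(N2N=C(c3ccc(F)cc3)CC2c2cn(-c3ccccc3)nc2-c2ccc(Cl)c(Cl)c2)cc1` differs from compound 3 by 4-nitrophenyl in place of hydrogen on an amine nitrogen in a ring. Among the measured compounds shown here, no measured pair isolates this exact change. For the measured compounds named here, the one step at the same place, from compound 2 to compound 3, stayed within the scatter. Compound 1 carries the same 4-nitrophenyl on that nitrogen, but it also differs elsewhere, so its higher value can only hint at where compound 4 might land.

Compound 4 is therefore expected to give about 52% in this assay, within roughly 42% to 62%. The expected step of a number 6.3 percentage points higher from compound 3 to compound 4 (within the scatter) is modest, upward, and may well fall within the scatter.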

Compound 4, a percentage reported as inhibition, in the whole organism at one dose (the size of the read-out at that dose, not a potency): 45.7%
Compound 4: middle estimate off by 6.3 percentage points, on the high side, within the range that was stated.
By their numbers in this assay, from the lowest: compounds 3, 4, 2 and 1 (each within the scatter of the next, the first and the last beyond it).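

Placing 4-nitrophenyl on this ring nitrogen gives no change at the digits printed from compound 3 to compound 4 (within the scatter) in this assay, and replacing propanoyl with it gives a number 5.4 percentage points lower from compound 2 to compound 4 (within the scatter), so hydrogen, propanoyl and 4-nitrophenyl cannot be told apart here. With 4-nitrophenyl held in place, the clearest difference comes from the other aromatic substituent, where fluoro in place of methyl gives a number 11.7 percentage points lower from compound 1 to compound 4 (beyond the scatter) and is the only single change shown that lies beyond the scatter. Nothing available explains either result.

On these data alone, whether any group on this nitrogen can move the number beyond the scatter remains open, for instance a benzyl group or a longer acyl chain such as butanoyl. As far as these compounds go, it is also open whether methyl on the aromatic ring would give a similar gain with propanoyl or hydrogen on the nitrogen.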